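This account rests on a few compounds, and the source may have more. Where it says the series, first, only, none or still open, it means among the compounds named here.

Compound 1 `O=C(O)CCNC(=O)c1ccc(CC(c2ccc(Cl)cc2)c2nc(-c3ccc(C(F)(F)F)cc3)cs2)cc1` was tested in an in vitro assay on BHK cells for binding affinity to Glucagon receptor (Homo sapiens) (a higher number here means a weaker inhibitor, a lower number a stronger inhibitor), where compound 1 gives 38 nM. Within the data shown here, the only other compound measured alongside it is compound 2 `O=C(O)CCNC(=O)c1ccc(CN(c2ccc(Cl)cc2)c2nc(-c3ccc(C(F)(F)F)cc3)cs2)cc1`, which in this assay gives 53 nM; the two numbers lie within the usual scatter of each other, so on these two measurements alone neither can be called the stronger binder. Compound 3 `O=C(O)CCNC(=O)c1ccc(CC(c2ccc(Cl)cc2)c2nc(-c3ccc(OC(F)(F)F)cc3)cs2)cc1` has not yet been measured in this assay. It differs from compound 1 in a single place: trifluoromethoxy in place of trifluoromethyl on an aromatic carbon. The exchange keeps everything else of the shared core of compound 1 untouched and adds only one oxygen and one hydrogen-bond acceptor at the outer edge of the molecule. Among the measured compounds shown here, no measured pair in this small set shows what this particular exchange does, so the expectation rests on its small size alone. The step expected from compound 1 to compound 3 in this assay is a 1.2-fold higher number from compound 1 to compound 3 (0.07 log units; within the scatter), that is, no change beyond the scatter in either direction. For compound 3 the estimated value in this assay is 45 nM, with a range from 15 nM to 140 nM.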

Compound 3, half-maximal inhibitory concentration: 25 nM
For compound 3 the middle estimate is 1.8-fold (0.26 log units) above the measured one; the measured number falls inside the stated range.
By their numbers in this assay, from the lowest: compounds 3, 1 and 2 (each within the scatter of the next, the first and the last beyond it).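

Compounds 1 and 3 are the only pair shown that differ at this outer position, where 4-(trifluoromethyl)phenyl becomes 4-(trifluoromethoxy)phenyl, and in this assay the exchange amounts to a 1.5-fold lower number from compound 1 to compound 3 (0.18 log units; within the scatter), so the two compounds cannot be told apart. On an aromatic carbon para to a large group, then, adding one oxygen and one hydrogen-bond acceptor leaves the number within the scatter of the value for compound 1, although a single pair cannot establish a general pattern. Nothing measured here explains why the number holds, and the data support no reading beyond the size of the step.

On these data alone, it remains open whether a group of a different kind at this same place, such as a nitrile, a methoxy group or an amine, would also stay within the scatter of compound 1 or would move the number clearly in either direction. As far as these compounds go, it is also open whether trifluoromethoxy in place of trifluoromethyl would give a similarly small step on the core of compound 2, which differs from compound 1 in its linking atom.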